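This account rests on a few compounds, and the source may have more. Where it says the series, first, only, none or still open, it means among the compounds named here.

Measured so far in an assay on isolated protein for inhibition of Indoleamine 2,3-dioxygenase 2 (Homo sapiens); a lower number here means a stronger inhibitor, a higher number a weaker inhibitor:
- Compound 1, `CC(C)(C)c1cn(CCNc2nonc2/C(=N/O)Nc2ccc(F)c(Br)c2)nn1`: 1870 nM
- Compound 2, `OCCc1cn(CCNc2nonc2/C(=N/O)Nc2ccc(F)c(Br)c2)nn1`: 1170 nM
- Compound 3, `CCC(O)c1cn(CCNc2nonc2/C(=N/O)Nc2ccc(F)c(Br)c2)nn1`: 947 nM

Of these three numbers, compound 3 gives the lowest, but the differences are small: the step of a 1.2-fold lower number from compound 2 to compound 3 (0.09 log units; within the scatter) and the step of a 2.0-fold lower number from compound 1 to compound 3 (0.30 log units; within the scatter) both stay inside the scatter of repeated measurements, so the three compounds cannot be separated with confidence.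

Compound 4, `CC(C)CC(C)(O)c1cn(CCNc2nonc2/C(=N/O)Nc2ccc(F)c(Br)c2)nn1`, shares the whole core with compound 3 and differs in one place: 1-hydroxy-1,3-dimethylbutyl in place of 1-hydroxypropyl on an aromatic carbon. The group that enters is a longer, more branched chain than the one that leaves, but it keeps the single hydroxyl.

Within the data shown here, two measured steps bear on this change. The step of a 2.0-fold lower number from compound 1 to compound 3 (0.30 log units; within the scatter) shows that replacing a branched alkyl without a hydroxyl by a shorter chain carrying one changed the number only within the scatter, and the step of a 1.2-fold lower number from compound 2 to compound 3 (0.09 log units; within the scatter) shows that moving from one hydroxyalkyl to another also stayed within the scatter. Nothing measured here shows that size or branching of this substituent shifts the number beyond the scatter.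

The step of a 1.0-fold higher number from compound 3 to compound 4 (0.00 log units; within the scatter) is therefore expected to stay within the scatter, in either direction. Compound 4 is estimated at 950 nM, with a range from 400 nM to 2200 nM.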

Compound 4, half-maximal inhibitory concentration: 689 nM
For compound 4 the middle estimate is 1.4-fold (0.14 log units) above the measured one; low and high end bracket the measured number.
By their numbers in this assay, from the lowest: compounds 4, 3, 2 and 1 (each within the scatter of the next, the first and the last beyond it).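

In this assay, the group on this aromatic carbon can grow from 1-hydroxypropyl, with 4 heavy atoms, to 1-hydroxy-1,3-dimethylbutyl, with 7, and the result is a 1.4-fold lower number from compound 3 to compound 4 (0.14 log units; within the scatter) and also a 1.7-fold lower number from compound 2 to compound 4 (0.23 log units; within the scatter), so this larger, branched chain costs nothing that can be told from the scatter. The first separation among these compounds comes from a 2.7-fold lower number from compound 1 to compound 4 (0.43 log units; beyond the scatter), a modest step, although compound 2 and compound 3 each remain within the scatter of both compound 1 and compound 4. No measurement available here explains that step, so it cannot be assigned to the hydroxyl or to any other feature of the chain.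

Going by these compounds, it remains open whether the hydroxyl of compound 4 matters at all, or whether a plain alkyl chain of the same length would give a similar number in this assay. Also open, on these data alone, is whether a longer chain, an amine or a carboxylic acid on this aromatic carbon would move the number well beyond the scatter, in either direction.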